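A saturated bicycle gives way to a benzothiophene

The source may hold more compounds than are shown below. What is called first, only, known or untested is meant among the compounds shown, and "the series" means these compounds.

The measured compounds and their values in a functional assay on A2780 cells (Homo sapiens) for cytotoxicity, read by MTT assay, with a stated time of 72 h (on this read-out lower numbers stand for stronger inhibition and higher numbers for weaker inhibition), are:
compound 1, `CN1[C@@H]2c3[nH]c4ccccc4c3C[C@H]1[C@H](C#N)N1[C@@H](CN3C(=O)c4ccccc4C3=O)c3[nH]c4ccccc4c3C[C@@H]21`, 80 nM;
compound 2, `CN1[C@@H]2c3[nH]c4ccccc4c3C[C@H]1[C@H](C#N)N1[C@@H](CNC(=O)c3cccc(C(F)(F)F)c3)c3[nH]c4ccccc4c3C[C@@H]21`, 210 nM;
compound 3, `CN1[C@@H]2c3[nH]c4ccccc4c3C[C@H]1[C@H](C#N)N1[C@@H](CNC(=O)c3cccc4c3CCCC4)c3[nH]c4ccccc4c3C[C@@H]21`, 810 nM.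

Compound 3 stands at the highest number of the three. Its nearest neighbour is compound 2, reached by a 3.9-fold higher number from compound 2 to compound 3 (0.59 log units; beyond the scatter). Among the compounds with values here, compound 1, which carries a phthalimide instead of an open amide, shows a lower number still, and no single-point step links it to compound 3, so only the two values can be set side by side.

The next compound, compound 4, is `CN1[C@@H]2c3[nH]c4ccccc4c3C[C@H]1[C@H](C#N)N1[C@@H](CNC(=O)c3cc4ccccc4s3)c3[nH]c4ccccc4c3C[C@@H]21`. It differs from compound 3 by 1-benzothiophen-2-yl in place of 1,2,3,4-tetrahydronaphthalen-5-yl on a carbonyl carbon. Within the data shown here, only one measured step touches the same position, the change on the carbonyl carbon recorded as a 3.9-fold higher number from compound 2 to compound 3 (0.59 log units; beyond the scatter), and it was modest. Among the measured compounds shown here, compound 4 introduces a fully aromatic bicycle in place of the partly saturated one, and no measured pair tells how such a swap reads out. A step of modest size, if any, is therefore expected, more likely toward a lower number than a higher one, as a 1.6-fold lower number from compound 3 to compound 4 (0.21 log units; within the scatter). On that basis compound 4 is estimated at 500 nM in this assay, with a plausible range from 150 nM to 1600 nM.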

Compound 4, half-maximal inhibitory concentration: 20 nM
For compound 4 the middle estimate is 25-fold (1.40 log units) above the measured one, and the stated range ends above it.
By their numbers in this assay, from the lowest: compound 4; then compound 1; then compound 2; then compound 3.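

The position on the carbonyl carbon proves far more responsive than the earlier step of a 3.9-fold higher number from compound 2 to compound 3 (0.59 log units; beyond the scatter) suggested: in this assay, the change to 1-benzothiophen-2-yl gives a 41-fold lower number from compound 3 to compound 4 (1.61 log units; beyond the scatter), a large step in the opposite direction. The new group also outdoes the 3-(trifluoromethyl)phenyl amide, with an 11-fold lower number from compound 2 to compound 4 (1.02 log units; beyond the scatter), so the open amides now span a wide range of values that turns entirely on the group on this carbonyl carbon. Compound 4 also passes the phthalimide, with a 4.0-fold lower number from compound 1 to compound 4 (0.60 log units; beyond the scatter), and so holds the lowest number of the four, whereas the open amides compound 2 and compound 3 both stand above compound 1.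

The compounds shown leave open whether the drop follows the sulfur, the five-membered aromatic ring or the loss of the non-aromatic ring, as this one step changes all three together, and a benzofuran-2-yl or naphthalen-2-yl group on the same carbonyl carbon would begin to separate them. Nothing available here offers an explanation for the size of this step.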